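Nitro to Sulfamoyl Where Both Parents Sit at the Limit

The source may hold more compounds than are shown below. What is called first, only, known or untested is meant among the compounds shown, and "the series" means these compounds.

Compound 2 `N#CC1=C(N)Oc2c(c3nc4ccccc4nc3c3ccccc23)C12C(=O)N(Cc1cnnn1-c1ccc([N+](=O)[O-])cc1)c1ccccc12` was tested in an ADME assay on L02 cells (Homo sapiens) for antiproliferative activity, read by MTT assay, with a stated time of 48 h; on this read-out higher numbers stand for weaker inhibition and lower numbers for stronger inhibition. In this assay compound 2 gives > 50000 nM, which is a limit of the assay rather than a number. Its nearest measured relative, compound 1 `Cc1ccccc1-n1nncc1CN1C(=O)C2(C(C#N)=C(N)Oc3c2c2nc4ccccc4nc2c2ccccc32)c2ccccc21`, differs only in carrying 2-methylphenyl in place of 4-nitrophenyl on an aromatic nitrogen. In this assay compound 1 gives > 50000 nM, again a limit. For the measured compounds named here, the one measured step, a step that the two limits leave unreadable from compound 1 to compound 2, runs between two values at the limit of > 50000 nM in this assay, at which 2 of the 2 values shown sit. Compound 3 `N#CC1=C(N)Oc2c(c3nc4ccccc4nc3c3ccccc23)C12C(=O)N(Cc1cnnn1-c1ccc(S(N)(=O)=O)cc1)c1ccccc12` carries the change (sulfamoyl in place of nitro on an aromatic carbon). Going by the values given here, no measured step bears on this change, and nothing so far points away from the limit. For compound 3 the expected value is 50000 nM, between 20000 nM and 120000 nM. The step thus expected is a number no higher from compound 2 to compound 3 (the limit leaves the size open).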

Compound 3, half-maximal inhibitory concentration: > 50000 nM
Compound 3: only a limit was reported; the forecaster's own chance of this, stated with the estimate: 75%; the middle value sits exactly at the limit.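

No step can be read among compound 1, compound 2 and compound 3, because each gives only a limit rather than a number: the limit of > 50000 nM in this assay, at which 3 of the 3 values shown sit.

On these data alone, the true value of each compound remains open, as does whether swapping these groups changes it.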